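Swapping the allyl arm of a naphthol for a pyridylmethyl arm

The source may hold more compounds than are shown below. What is called first, only, known or untested is meant among the compounds shown, and "the series" means these compounds.

Measured compounds:
Compound 1, `C=CCc1ccc2ccccc2c1O`, gives 56 nM in an assay on RBL-1 cells with Polyunsaturated fatty acid 5-lipoxygenase (Rattus norvegicus) as the target; on this read-out lower numbers stand for stronger inhibition and higher numbers for weaker inhibition.
Compound 2, `Cc1ccc(Cc2ccc3ccccc3c2O)cc1`, gives 24 nM in this assay.
Compound 3, `Cc1ccccc1Cc1ccc2ccccc2c1O`, gives 120 nM in this assay.

Among these three numbers compound 1 stands second highest. Compound 2 gives a lower number than compound 1, and compound 3 a higher one, and both of those gaps lie beyond the usual scatter of repeated measurements. So a benzyl-type arm on the shared core can land on either side of the allyl arm of compound 1.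

Compound 4, `Oc1c(Cc2cccnc2)ccc2ccccc12`, is the compound still to be measured. It differs from compound 1 in one place: pyridin-3-yl in place of vinyl on a saturated chain carbon bound to an aromatic carbon. Among the measured compounds shown here, no pair of measured compounds differing in one place is available, so the size of this step has to be judged from the spread seen so far, and the spread is modest. No step beyond the scatter is expected in this assay, in either direction. For compound 4 the expected value is 60 nM, with a range from 20 nM to 200 nM, which would make the step from compound 1 to compound 4 come out as a 1.1-fold higher number from compound 1 to compound 4 (0.03 log units; within the scatter).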

Compound 4, half-maximal inhibitory concentration: 230 nM
Beside the measured number, compound 4's estimate is 3.8-fold (0.58 log units) below it; the whole stated range lies below it.
By their numbers in this assay, from the lowest: compound 2; then compound 1; then compounds 3 and 4 (each within the scatter of the next).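

In this assay, putting pyridin-3-yl in place of vinyl on a saturated chain carbon bound to an aromatic carbon gives a 4.1-fold higher number from compound 1 to compound 4 (0.61 log units; beyond the scatter), so inhibition weakens with this change. Among the compounds shown here, this is the first step in the set that alters only one place, so the effect of this swap can be read directly rather than judged from the general spread of the numbers. No measurement at hand bears on the reason for this step.

The swap brings in a ring and a ring nitrogen together, and the compounds shown cannot separate the two. An unsubstituted phenyl on the same carbon would help to tell them apart, while pyridin-2-yl, pyridin-4-yl or an amine on a longer chain could show whether the step depends on where the nitrogen sits.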